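Allyl to 2-hydroxyethyl on the side chain

A few compounds are considered here, and "the series" means these few. Any claim that something is new, unique, unknown or untested is made for them only; others in the source may bear on it.

Measured in a functional assay on HCT-116 cells (Homo sapiens) for antiproliferative activity, read by sulforhodamine B assay, with a stated time of 72 h; on this read-out higher numbers stand for weaker inhibition and lower numbers for stronger inhibition:
- compound 1 `Cn1ncc(Cl)c1-c1cc(C(=O)N[C@@H]2CN[C@H](CC(O)CO)C[C@H]2c2ccc(Cl)c(Cl)c2)oc1Cl` gives 1110 nM
- compound 2 `Cn1ncc(Cl)c1-c1cc(C(=O)N[C@@H]2CN[C@H](CCCO)C[C@H]2c2ccc(Cl)c(Cl)c2)oc1Cl` gives 510 nM
- compound 3 `C=CC[C@@H]1C[C@@H](c2ccc(Cl)c(Cl)c2)[C@H](NC(=O)c2cc(-c3c(Cl)cnn3C)c(Cl)o2)CN1` gives 780 nM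

Compound 3 lies within the scatter of both compound 1 and compound 2, although those two are modestly separated: a 2.2-fold lower number from compound 1 to compound 2 (0.34 log units; beyond the scatter). Compound 4 `Cn1ncc(Cl)c1-c1cc(C(=O)N[C@@H]2CN[C@H](CCO)C[C@H]2c2ccc(Cl)c(Cl)c2)oc1Cl` carries hydroxymethyl in place of vinyl on a saturated chain carbon bound to a saturated ring carbon. The closest measured steps also exchange the vinyl for hydroxylated groups at this place, and both stay within the scatter: a 1.5-fold higher number from compound 2 to compound 3 (0.18 log units; within the scatter) and a 1.4-fold lower number from compound 1 to compound 3 (0.15 log units; within the scatter). No step beyond the scatter is therefore expected in this assay. The expected step is a 1.1-fold lower number from compound 3 to compound 4 (0.06 log units; within the scatter). For compound 4 the estimated value is 680 nM, with an expected range of 330 nM to 1400 nM.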

Compound 4, half-maximal inhibitory concentration: 340 nM
For compound 4 the middle estimate is 2.0-fold (0.30 log units) above the measured one; measured number inside the range.
By their numbers in this assay, from the lowest: compounds 4, 2, 3 and 1 (each within the scatter of the next, the first and the last beyond it).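

In this assay, among these compounds, allyl to 2-hydroxyethyl is the only exchange of the allyl at this place that passes the scatter, giving a 2.3-fold lower number from compound 3 to compound 4 (0.36 log units; beyond the scatter). Among the hydroxylated side chains the result is mixed, with a 1.5-fold lower number from compound 2 to compound 4 (0.18 log units; within the scatter) and a 3.3-fold lower number from compound 1 to compound 4 (0.51 log units; beyond the scatter), so the presence of hydroxy alone does not set the number. No available measurement explains these steps. Going by these compounds, whether an amine, a carboxylic acid or a methyl ether in place of the hydroxy of compound 4 would keep its number stays open.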